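This account rests on a few compounds, and the source may have more. Where it says the series, first, only, none or still open, it means among the compounds named here.

Series notes. The shared core of compound 1 `COc1cc(-c2nnc(SCC(=O)Nc3ccc(/C(C)=N/O)cc3)n2-c2ccccc2)cc(OC)c1OC` carries a trimethoxyphenyl group and a phenyl group on the heterocycle; in a functional assay on the whole organism (strain albino) for inhibition, with Rattus norvegicus as the target, read by paw edema, with stated times of 30 min and 1 h, at a dose of 0.28 mmol/kg by the oral route (on this read-out higher numbers stand for more inhibition at the one dose given (going by the name of the read-out) and lower numbers for less inhibition), compound 1 gives 59%. Compound 2 `CCn1c(SCC(=O)Nc2ccc(/C(C)=N/O)cc2)nnc1-c1ccc(OC)c(OC)c1` bears an ethyl group in place of that phenyl and a dimethoxyphenyl group, and in this assay compound 2 gives 53%. Compound 3 `CCn1c(SCC(=O)Nc2ccc(/C(C)=N/O)cc2)nnc1-c1ccc(OC)cc1` keeps the ethyl group and has a single methoxy on the phenyl; in this assay compound 3 gives 54%.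

Compound 2 stands lowest of the three numbers, but its nearest neighbour compound 3 and its furthest neighbour compound 1 both lie within the scatter of it, so no order among the three can be read.

Compound 4 `CCn1c(SCC(=O)Nc2ccc(/C(C)=N/O)cc2)nnc1-c1cc(OC)c(OC)c(OC)c1` differs from compound 2 by methoxy in place of hydrogen on an aromatic carbon. Among the measured compounds shown here, the one measured step that bears on this change is the removal of a methoxy group at a neighbouring site, a number 1 percentage points higher from compound 2 to compound 3 (within the scatter), which did nothing beyond the scatter. Compound 1, which also carries three methoxy groups, shows a number close to that of compound 2. A step of a number 2 percentage points higher from compound 2 to compound 4 (within the scatter) is therefore expected, meaning none beyond the scatter. In this assay compound 4 is estimated at 55%, with a range from 45% to 65%.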

Compound 4, a percentage reported as inhibition, in the whole organism at one dose (the size of the read-out at that dose, not a potency): 29%
Estimate against measurement, compound 4: 26 percentage points above; measured number outside the range, below it.
By their numbers in this assay, from the lowest: compound 4; then compounds 2, 3 and 1 (each within the scatter of the next).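

In this assay, methoxy in place of hydrogen on the aromatic carbon ortho to a methoxy group gives a number 24 percentage points lower from compound 2 to compound 4 (beyond the scatter), whereas the earlier change at the neighbouring site gave only a number 1 percentage points higher from compound 2 to compound 3 (within the scatter). Methoxy substitution on this ring is therefore not interchangeable from one position to the next, and the earlier flat numbers do not extend to this position when the ethyl group is present. The three methoxy groups do not bring a low number on their own either: ethyl in place of phenyl on the aromatic nitrogen gives a number 30 percentage points lower from compound 1 to compound 4 (beyond the scatter), so the outcome of this ring pattern depends on the group on that nitrogen.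

Still open, going by these compounds, is whether the fall is specific to methoxy at this position or would also appear with a hydroxyl group, an ethoxy group or an amine there, and whether a longer chain such as propyl or butyl on the nitrogen would behave like ethyl or like phenyl. Nothing available here accounts for the fall at this position.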